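The compounds below may be only part of what the source reports. "The series", "measured", "known", "first", "only" and "open" are said of these compounds alone.

Measured compounds:
compound 1 `Cc1ccc(-c2ccc(Cl)c(C(=O)NCC3(O)CCCCCC3)c2)nn1` with 18 nM in a functional assay on HEK293 cells for antagonist activity at P2X purinoceptor 7 (Homo sapiens); a lower number here means a stronger inhibitor, a higher number a weaker inhibitor
compound 2 `O=C(NCC1(O)CCCC(F)(F)C1)c1cc(-c2ncc(F)cn2)ccc1Cl` with 51 nM in this assay

Compound 1 stands at the lowest of the two numbers, and its gap to compound 2 lies beyond the scatter. Compound 3 `Cc1cnc(-c2ccc(Cl)c(C(=O)NCC3(O)CCCCCC3)c2)nc1` has not been measured; it differs from compound 1 by 5-methylpyrimidin-2-yl in place of 6-methylpyridazin-3-yl on an aromatic carbon. Going by the values given here, no step between measured compounds describes this change, so the expectation for compound 3 rests on the standing of compound 1 alone. A small step is expected, a 1.7-fold higher number from compound 1 to compound 3 (0.22 log units; within the scatter), toward a weaker number and possibly within the scatter. Compound 3 is estimated at 30 nM, in a range from 10 nM to 90 nM.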

Compound 3, half-maximal inhibitory concentration: 8 nM
Compound 3: middle estimate off by 3.8-fold (0.57 log units), on the high side; measured number below the stated range.
By their numbers in this assay, from the lowest: compound 3; then compound 1; then compound 2.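

At this position, on an aromatic carbon para to a chloro group, 5-methylpyrimidin-2-yl in place of 6-methylpyridazin-3-yl gives a 2.3-fold lower number from compound 1 to compound 3 (0.35 log units; beyond the scatter) in this assay, a modest step beyond the scatter. The two groups have the same atoms and the same counts of hydrogen-bond donors and acceptors, so a rearrangement within this group alone is enough to move the number toward a stronger inhibitor. Nothing measured here accounts for the step. Still open, going by these compounds, is how much of the number depends on the methyl of 5-methylpyrimidin-2-yl, and whether a methoxy or trifluoromethyl group in its place would hold the standing of compound 3.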